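Permeability notes on the carboxylic acid series

This account rests on a few compounds, and the source may have more. Where it says the series, first, only, none or still open, it means among the compounds named here.

Measured compounds:
compound 1 `CC(C)Cc1cc2oc(=O)n(CCC(=O)O)c2cc1Cl` — < 10 nm/s
compound 2 `Cc1ccnc([C@@H](C)Oc2cc3oc(=O)n(CCC(=O)O)c3cc2Cl)c1` — < 3 nm/s
compound 3 `C[C@@H](Oc1cc2oc(=O)n(CCC(=O)O)c2cc1Cl)c1ccc(Cl)cn1` — 60 nm/s

In a physicochemical assay for permeability, using PAMPA (a lower number here means that the compound crosses the layer more slowly, a higher number that the compound crosses the layer faster), compound 1 gives < 10 nm/s, which is a limit of the assay and not a number. Compound 2 likewise gives < 3 nm/s, again a limit rather than a number. Within the data shown here, compound 3 is the one member with a measured number, 60 nm/s. Among the measured compounds shown here, the single measured step, an at least 20-fold higher number from compound 2 to compound 3 (1.30 log units; beyond the scatter), concerns 5-chloropyridin-2-yl in place of 4-methylpyridin-2-yl on the saturated chain carbon bound to an oxygen on an aromatic ring and a saturated chain carbon, a position not involved in the step considered here.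

Compound 4 `CCc1cc2oc(=O)n(CCC(=O)O)c2cc1Cl` differs from compound 1 by methyl in place of isopropyl on a saturated chain carbon bound to an aromatic carbon. For the measured compounds named here, no measured pair touches this position, so the step has no direct precedent in this assay. Compound 1 stands at the limit of < 10 nm/s in this assay, at which 1 of the 3 values shown sits, so only a ceiling is known for its starting point. Going by the values given here, with no measured step pointing either way, the expectation for compound 4 is that it remains at or near the same limit. For compound 4 the estimated value is 5 nm/s, with a range from 1.5 nm/s to 15 nm/s. The estimated step that the limit leaves unreadable from compound 1 to compound 4 is expected to stay within the scatter.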

Compound 4, apparent permeability: < 10 nm/s
Compound 4 was reported as a limit; the forecaster's own chance of this, stated with the estimate: 70%; the middle value lies beyond the limit too.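

In this assay compound 4 gives < 10 nm/s, which is a limit and not a number. Compound 1 gives < 10 nm/s, also a limit, so the step from it to compound 4 cannot be read. The compounds shown leave open whether methyl in place of isopropyl changes the read-out at all.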